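The source may report more compounds than this note shows. Statements on the series, on what has been measured and on what is new or still open speak of the compounds shown alone.

Measured so far:
compound 1 `O=C(NNc1ccccc1Cl)c1ccc(NS(=O)(=O)c2cnc(O)nc2O)cc1` gives 3340 nM in a functional assay on A549 cells (Homo sapiens) for antiproliferative activity, read by MTT assay, with a stated time of 24 h; a lower number here means a stronger inhibitor, a higher number a weaker inhibitor
compound 2 `O=C(NNc1ccccc1F)c1ccc(NS(=O)(=O)c2cnc(O)nc2O)cc1` gives 11700 nM in this assay

Among the measured compounds shown here, compound 2 stands with the higher number of the two; the only measured step, a 3.5-fold higher number from compound 1 to compound 2 (0.54 log units; beyond the scatter), separates them. Compound 3 `O=C(NNC(=O)c1ccccc1Cl)c1ccc(NS(=O)(=O)c2cnc(O)nc2O)cc1` is not yet measured. Change from compound 2: (2-chlorophenyl)carbonyl in place of 2-fluorophenyl on an amine nitrogen. For the measured compounds named here, the measured step bears on this only through the halogen, since chloro comes back in compound 3; the entering carbonyl has no precedent. A modest move toward a lower number in this assay is therefore expected, with wide uncertainty. Compound 3 is expected at 4500 nM (range 1500 nM to 13000 nM), a step of a 2.6-fold lower number from compound 2 to compound 3 (0.41 log units; beyond the scatter) expected.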

Compound 3, half-maximal inhibitory concentration: 1900 nM
Compound 3: middle estimate off by 2.4-fold (0.37 log units), on the high side; measured number inside the range.
By their numbers in this assay, from the lowest: compounds 3 and 1 (each within the scatter of the next); then compound 2.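

In this assay the change on the amine nitrogen gives a 6.2-fold lower number from compound 2 to compound 3 (0.79 log units; beyond the scatter) with the halogen changing as well, so this step does not isolate the carbonyl. With chloro held constant, the carbonyl gives a 1.8-fold lower number from compound 1 to compound 3 (0.24 log units; within the scatter) and so no readable change at this position. No evidence on the cause of these differences is available.

Open, as far as these compounds go, is how (2-fluorophenyl)carbonyl would read against compound 2 and compound 3. Also open, from the compounds shown here alone, are 2-bromophenyl and unsubstituted phenyl on the same amine nitrogen.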